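Trading a phenoxy for a methoxy on the shared core

The source may hold more compounds than are shown below. What is called first, only, known or untested is meant among the compounds shown, and "the series" means these compounds.

Measured so far in an in vitro functional assay on SH-EP1 cells for agonist activity at Neuronal acetylcholine receptor; alpha4/beta2 (Homo sapiens), read by FLIPR and calcium flux; on this read-out lower numbers stand for smaller maximal responses and higher numbers for larger maximal responses:
- compound 1 `C1=C(c2cncnc2)CC2CNCC1C2`: 145%
- compound 2 `COc1ccc(C2=CC3CC(C2)CN(C)C3)cn1`: 20%
- compound 3 `C1=C(c2cncc(Oc3ccccc3)c2)CC2CNCC1C2`: 30%

Among these three, compound 3 gives the second highest maximal response. Its nearest neighbour is compound 2, whose number lies within the usual scatter of this assay, so the two cannot be told apart. Compound 1 stands far above both, well beyond the scatter.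

Compound 4 `COc1cncc(C2=CC3CNCC(C2)C3)c1` has not yet been measured. Compared with compound 3 it carries methyl in place of phenyl on an oxygen on an aromatic ring. The phenoxy group of compound 3 thus shrinks to a methoxy group, while the rest of the molecule is unchanged. Compound 2 also bears a methoxy group and gives a low maximal response, so the change is not expected to restore the large response seen for compound 1. The step from compound 3 to compound 4 in this assay is expected to be small, a number 10 percentage points higher from compound 3 to compound 4 (within the scatter), likely within the scatter. Compound 4 is estimated at 40%, with a range from 15% to 95%, because compound 2 gives 20% and compound 3 gives 30%.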

Compound 4, largest response reached (reported as percent of maximum), in percent of the reference or control that the assay uses: 100%
The estimate for compound 4 lay 60 percentage points below the measured number; the measured number lies above the stated range.
By their numbers in this assay, from the lowest: compounds 2 and 3 (each within the scatter of the next); then compound 4; then compound 1.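

On the shared core, the group on the oxygen on the aromatic ring has a strong hold on the maximal response: in this assay, methyl in place of phenyl gives a number 70 percentage points higher from compound 3 to compound 4 (beyond the scatter), with the rest of the molecule unchanged. Among these compounds, the earlier compounds could not show this, since no two of them differ in one place only, so this is the first change that can be tied to a single group. What lies behind the rise remains unexplained, as no supporting data bear on it.

Only phenyl and methyl are shown on this oxygen, so it remains open how the response changes with an ethyl or isopropyl group there. As far as these compounds go, it is also open whether the oxygen itself is needed, which an amine or a plain methyl group in place of the methoxy would test.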